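This account rests on a few compounds, and the source may have more. Where it says the series, first, only, none or still open, it means among the compounds named here.

The measured compounds:
compound 1, `COc1cc(C(=O)NO)ccc1CN(C(C)C)S(=O)(=O)c1cc(F)c(F)c(F)c1F`, 474 nM
compound 2, `CC(C)CN(Cc1ccc(C(=O)NO)cc1)S(=O)(=O)c1cc(F)c(F)c(F)c1F`, > 1000 nM
compound 3, `CC(C)N(Cc1ccc(C(=O)NO)cn1)S(=O)(=O)c1cc(F)c(F)c(F)c1F`, > 1000 nM

All three share a core and were tested in an assay on Sf9 cells for inhibition of histone deacetylase 8 (Homo sapiens), read by fluorescence and mobility shift assay; on this read-out lower numbers stand for stronger inhibition and higher numbers for weaker inhibition. Compound 1 gives a number, 474 nM. For compound 2 this assay reports only a limit, > 1000 nM, and not a number. Compound 3 likewise stops at a limit, > 1000 nM. So compound 2 stands at the limit of > 1000 nM in this assay, at which 2 of the 3 values shown sit, and nothing in the numbers says how far beyond it compound 2 lies.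

Compound 4, `COCCN(Cc1ccc(C(=O)NO)cc1)S(=O)(=O)c1cc(F)c(F)c(F)c1F`, is not yet measured. It differs from compound 2 in one place: methoxymethyl in place of isopropyl on a saturated chain carbon bound to a sulfonamide nitrogen. Among the measured compounds shown here, no measured pair shows this change, so its effect in this assay is unknown; the nearest comparison, compound 2 against compound 1, involves other differences as well. Because compound 2 sits at > 1000 nM, the step from compound 2 to compound 4 is expected to stay within the scatter, a step that the limit leaves unreadable from compound 2 to compound 4, with no clear direction. Compound 4 is therefore estimated at 1500 nM, between 400 nM and 6000 nM, and a limit rather than a number is the more likely outcome.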

Compound 4, half-maximal inhibitory concentration: > 1000 nM
Compound 4 ended at the assay's limit; the forecaster's own chance of this, stated with the estimate: 65%; the middle value lies beyond the limit too.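

Compound 2 and compound 4 both stop at a limit and not a number, so no step can be read between them: the limit of > 1000 nM in this assay, at which 3 of the 4 values shown sit.

The compounds shown leave open how far past that limit each lies, and whether methoxymethyl in place of isopropyl changes inhibition at all.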